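Toxicity notes on the step to compound 3

The source may hold more compounds than are shown below. What is called first, only, known or untested is meant among the compounds shown, and "the series" means these compounds.

- Compound 1 `COc1cccc(/C=C2\CCC/C(=C\c3ccc([N+](=O)[O-])cc3)C2=O)c1OC`: < 10000 nM (a limit)
- Compound 2 `COc1cccc(/C=C2\CCC/C(=C\c3cccc(Br)c3)C2=O)c1OC`: 31500 nM
- Compound 3 `COc1cccc(/C=C2\CCC/C(=C\c3c(Cl)cccc3Cl)C2=O)c1OC`: not yet measured

Within the data shown here, in an ADME assay on Vero cells (Chlorocebus sabaeus) for inhibition (on this read-out lower numbers stand for higher toxicity in this test and higher numbers for lower toxicity in this test), compound 2 gives 31500 nM, the only actual number so far. Compound 1 gives only a limit, < 10000 nM. The next change is 2,6-dichlorophenyl in place of 3-bromophenyl on a double-bonded chain carbon bound to a double-bonded ring carbon. Among the measured compounds shown here, one measured step bears on it: an at least 3.1-fold higher number from compound 1 to compound 2 (0.49 log units; beyond the scatter), which rests on (the limit of < 10000 nM in this assay, at which 1 of the 2 values shown sits). That step involves different groups, so its direction does not carry over, and no step beyond the scatter is expected. The expected step is a 1.3-fold lower number from compound 2 to compound 3 (0.10 log units; within the scatter). For compound 3, the estimate is 25000 nM, with an expected range of 9000 nM to 70000 nM.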

Compound 3, half-maximal cytotoxic concentration: 160000 nM
Compound 3: middle estimate off by 6.4-fold (0.81 log units), on the low side; the measured number lies above the stated range.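

In this assay, the change to 2,6-dichlorophenyl on a double-bonded chain carbon bound to a double-bonded ring carbon gives lower toxicity in this test (a 5.1-fold higher number from compound 2 to compound 3 (0.71 log units; beyond the scatter)). Among these compounds, the earlier step from the 4-nitrophenyl compound is thus not the only change here that moves the number beyond the scatter, since this one moves it between two halogen-bearing phenyl groups. The wider step (an at least 16-fold higher number from compound 1 to compound 3 (1.20 log units; beyond the scatter)) gives only a bound, as compound 1 has a limit and not a number: the limit of < 10000 nM in this assay, at which 1 of the 3 values shown sits.

The step from compound 2 to compound 3 swaps bromine for chlorine and also changes the halogen count and substitution pattern, so these contributions remain unseparated. A 2-chlorophenyl or 3-chlorophenyl group, or an amine or carboxylic acid on the phenyl ring, would leave open how far the higher number extends.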